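Cytotoxicity on KB cells: From Propoxy to Chlorobenzyloxy

The source may report more compounds than this note shows. Statements on the series, on what has been measured and on what is new or still open speak of the compounds shown alone.

Measured so far:
- compound 1 `CCCCOc1c(OC)c(OC)cc2c1C(=O)[C@]1(OC)C=C[C@H]2N(C(=O)OCC)N1C(=O)OCC`: 76 ug/mL
- compound 2 `COC(=O)N1[C@@H]2C=C[C@@](OC)(C(=O)c3c2cc(OC)c(OC)c3OCc2ccc(OC)cc2)N1C(=O)OC`: a limit, see below
- compound 3 `CCCOc1c(OC)c(OC)cc2c1C(=O)[C@]1(OC)C=C[C@H]2N(C(=O)OCC(C)C)N1C(=O)OCC(C)C`: 299 ug/mL

In an ADME assay on KB cells (Homo sapiens) for cytotoxicity (on this read-out higher numbers stand for an effect only at larger amounts of compound and lower numbers for an effect already at smaller amounts), compound 3 stands at the highest of the two numbers that were obtained. Its nearest neighbour is compound 1, whose number in this assay is lower by a gap that lies beyond the usual scatter of this measurement. Compound 2 gives only a limit in this assay, namely > 300 ug/mL, so it is not a number (the limit of > 300 ug/mL in this assay, at which 1 of the 3 values shown sits).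

Compound 4 `COc1cc2c(c(OCc3ccc(Cl)cc3)c1OC)C(=O)[C@]1(OC)C=C[C@H]2N(C(=O)OCC(C)C)N1C(=O)OCC(C)C` has not yet been measured. It differs from compound 3 in one place (4-chlorophenyl in place of ethyl on a saturated chain carbon bound to an oxygen on an aromatic ring). No step between two measured compounds covers this exact change, so the expectation rests on the position of compound 3 close to the limit of this assay and on the limit shown by compound 2. For compound 4 the expected step is a 1.0-fold higher number from compound 3 to compound 4 (0.00 log units; within the scatter), small or none beyond the scatter. Compound 4 is therefore expected to give about 300 ug/mL in this assay, within a range from 120 ug/mL to 700 ug/mL, and a report of only a limit is quite possible.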

Compound 4, concentration for half-maximal effect: 42 ug/mL
For compound 4 the middle estimate is 7.1-fold (0.85 log units) above the measured one, outside the stated range (below it).
By their numbers in this assay, from the lowest: compounds 4 and 1 (each within the scatter of the next); then compound 3. At a limit, above all of these: compound 2.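

In this assay the place on a saturated chain carbon bound to an oxygen on an aromatic ring proves sensitive to what sits there: with the rest of the molecule unchanged, 4-chlorophenyl in place of ethyl, which is propoxy becoming (4-chlorobenzyl)oxy, gives a 7.1-fold lower number from compound 3 to compound 4 (0.85 log units; beyond the scatter). This single change is therefore enough to move a compound from close to the limit of this read-out to an effect at clearly smaller amounts. Nothing shown here gives a reason for this step.

This one pair cannot separate the contribution of the aromatic ring from that of the chlorine. A plain benzyl group, a 4-fluorobenzyl group or a longer chain such as hexyl at this place would show which part of the new group goes with the step.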